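Swapping a Benzyl Amide for a Methylphenyl Amide

A few compounds are considered here, and "the series" means these few. Any claim that something is new, unique, unknown or untested is made for them only; others in the source may bear on it.

Measured compounds:
compound 1 `COc1cccc(NC(=O)/C=C/c2coc3cc(OC)ccc3c2=O)c1` — 39100 nM
compound 2 `COc1ccc2c(=O)c(/C=C/C(=O)NCc3cccc(F)c3)coc2c1` — 28600 nM

In a functional assay (QGY7701 cells, Homo sapiens) for inhibition, read by MTT assay, with a stated time of 48 h (on this read-out lower numbers stand for stronger inhibition and higher numbers for weaker inhibition), compound 2 gives 28600 nM, the lowest of the two numbers, though the step of a 1.4-fold lower number from compound 1 to compound 2 (0.14 log units; within the scatter) lies within the scatter. Compound 3 `COc1ccc2c(=O)c(/C=C/C(=O)Nc3ccccc3C)coc2c1` differs from compound 2 by 2-methylphenyl in place of 3-fluorobenzyl on an amide-type nitrogen. Within the data shown here, the only measured step, a 1.4-fold lower number from compound 1 to compound 2 (0.14 log units; within the scatter), also exchanged the group on the same nitrogen and stayed within the scatter, and compound 1 itself carries a phenyl-type group there. Compound 3 is therefore expected to land near both neighbours, at an estimated 35000 nM, ranging from 15000 nM to 80000 nM. The expected step is a 1.2-fold higher number from compound 2 to compound 3 (0.09 log units; within the scatter).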

Compound 3, half-maximal inhibitory concentration: 22500 nM
Compound 3: middle estimate off by 1.6-fold (0.19 log units), on the high side; low and high end bracket the measured number.
By their numbers in this assay, from the lowest: compounds 3, 2 and 1 (each within the scatter of the next).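

In this assay, a 1.3-fold lower number from compound 2 to compound 3 (0.10 log units; within the scatter) and a 1.7-fold lower number from compound 1 to compound 3 (0.24 log units; within the scatter) both stay within the scatter, so this amide-type nitrogen has now carried three different aromatic groups without a step beyond it. The 2-methylphenyl group of compound 3 cannot be told apart by this read-out from the 3-fluorobenzyl of compound 2 or the 3-methoxyphenyl of compound 1. Nothing measured here explains why these groups read alike. Going by these compounds, whether a group of another kind on this nitrogen, such as a carboxylic acid or a longer chain ending in an amine, would shift the number stays open. So does whether any such swap could bring a step beyond the scatter.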